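Fluorophenyl to fluorobenzyl on an aromatic nitrogen

A few compounds are considered here, and "the series" means these few. Any claim that something is new, unique, unknown or untested is made for them only; others in the source may bear on it.

Measured so far in a functional assay on MCF7 cells (Homo sapiens) for antiproliferative activity, read by MTT assay, with a stated time of 48 h; on this read-out higher numbers stand for weaker inhibition and lower numbers for stronger inhibition:
compound 1 `COc1ccc(OC)c(/C=N/c2c(C#N)ncn2-c2ccc(F)cc2)c1` gives 7090 nM
compound 2 `N#Cc1ncn(-c2ccc(F)cc2)c1/N=C/c1ccc([N+](=O)[O-])cc1` gives 9100 nM
compound 3 `COc1ccc(OC)c(/C=N/c2c(C#N)ncn2Cc2ccc(F)cc2)c1` gives 10900 nM

Within the data shown here, all three numbers are close together; none of the gaps between them is large enough to stand out from the ordinary scatter of this kind of measurement, so no compound can be called stronger or weaker than another here.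

Compound 1 and compound 3 differ in one place only: 4-fluorobenzyl in place of 4-fluorophenyl on an aromatic nitrogen. The step in this assay that came with it is a 1.5-fold higher number from compound 1 to compound 3 (0.19 log units; within the scatter), a change too small to mean anything on its own.

Compound 2 shares the five-membered ring, its cyano group and the 4-fluorophenyl of compound 1, but the rest of the molecule differs; that difference between the two cores is not broken down here.

Compound 4 `N#Cc1ncn(Cc2ccc(F)cc2)c1/N=C/c1ccc([N+](=O)[O-])cc1` has not yet been measured. It relates to compound 2 as compound 3 relates to compound 1: 4-fluorobenzyl in place of 4-fluorophenyl on an aromatic nitrogen. The place of the change is described in the same words for both pairs, so this is the same change made on a different core.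

Among the measured compounds shown here, with only one earlier example, the expectation rests on the step from compound 1 to compound 3, which was within the scatter. The step from compound 2 to compound 4 in this assay is therefore expected to be small, about a 1.3-fold higher number from compound 2 to compound 4 (0.12 log units; within the scatter). Compound 4 is estimated at 12000 nM, likely between 5500 nM and 26000 nM.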

Compound 4, half-maximal inhibitory concentration: 10600 nM
Compound 4: the middle estimate sits 1.1-fold (0.05 log units) above what was measured, within the range that was stated.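

In this assay, putting 4-fluorobenzyl in place of 4-fluorophenyl on the aromatic nitrogen gives a 1.2-fold higher number from compound 2 to compound 4 (0.07 log units; within the scatter), so on this second core the step is again too small to mean anything on its own. Set side by side, the two steps do not differ from each other in any way that can be told from ordinary scatter: the same change on two cores in this assay, a 1.5-fold higher number (0.19 log units; within the scatter) from compound 1 to compound 3 and a 1.2-fold higher number (0.07 log units; within the scatter) from compound 2 to compound 4, 1.3-fold (0.12 log units) apart, within the scatter of two such steps

This shows that, in these two pairs, the change leaves the read-out about where it was on both cores, so the small step seen on the first core also held on the second. It does not show that the change has a real effect in either direction, even though both numbers are printed as higher, and two pairs are too few to establish a rule for the whole series.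

The compounds shown leave open whether a different group on that nitrogen, such as a longer chain ending in a phenyl ring or a chain carrying an amine, would give a step beyond the scatter. They also leave open whether the same change would stay this small on a core with another group in place of the cyano group, such as a carboxylic acid.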